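Cyano for methyl on the aryl ring of compound 2

The source may hold more compounds than are shown below. What is called first, only, known or untested is meant among the compounds shown, and "the series" means these compounds.

Among the measured compounds shown here, compound 2 `Cc1cccc(-c2nnn(CC(=O)Nc3cc(C)nn3C3CCCCC3)n2)c1` gives 93% in an assay on HEK293 cells for activation of Kir3.1/Kir3.2 (Homo sapiens), read by thallium flux (a lower number here means a smaller maximal response, a higher number a larger maximal response), the higher of the two numbers measured so far; compound 1 `Cc1ccc(-c2nnn(CC(=O)Nc3cc(C)nn3C3CCCCC3)n2)cc1` gives 86%, and the step is a number 7 percentage points higher from compound 1 to compound 2 (within the scatter). Compound 3 `Cc1cc(NC(=O)Cn2nnc(-c3cccc(C#N)c3)n2)n(C2CCCCC2)n1` introduces (cyano in place of methyl on an aromatic carbon). For the measured compounds named here, the only measured step on this ring bears on it indirectly and stayed within the scatter; no measured step brings in a cyano group. The maximal response is therefore expected to move little, an estimated a number 8 percentage points lower from compound 2 to compound 3 (within the scatter). For compound 3 the expected value is 85%, within a range from 65% to 100%.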

Compound 3, largest response reached (Emax), in percent of the reference or control that the assay uses: 80%
For compound 3 the middle estimate is 5 percentage points above the measured one; low and high end bracket the measured number.
By their numbers in this assay, from the lowest: compounds 3, 1 and 2 (each within the scatter of the next, the first and the last beyond it).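

On the aryl ring, at the carbon meta to a large group, cyano in place of methyl gives the only step shown beyond the scatter in this assay (a number 13 percentage points lower from compound 2 to compound 3 (beyond the scatter)), and that step is modest. Measured against the 4-methylphenyl analogue, the 3-cyanophenyl group stays within the scatter (a number 6 percentage points lower from compound 1 to compound 3 (within the scatter)), so the nitrile separates compound 3 from compound 2 only. No available data explain this step.

Open, on these data alone, is whether other groups at this carbon, such as chlorine, methoxy or an amine, keep the maximal response of compound 2 or fall with the nitrile. Also open, as far as these compounds go, is how 4-cyanophenyl compares with 3-cyanophenyl.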